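The source may hold more compounds than are shown below. What is called first, only, known or untested is meant among the compounds shown, and "the series" means these compounds.

In a functional assay on PANC-1 cells (Homo sapiens) for inhibition, read by XTT assay, with a stated time of 72 h (a higher number here means a weaker inhibitor, a lower number a stronger inhibitor), compound 1 `CCCCCCCC/C=C\CCCCCCCCOC[C@@H]1CCCN1` gives 4700 nM and compound 2 `CCCCCCCC/C=C/CCCCCCCCOC[C@@H]1CCCN1` gives 5300 nM, so the two stand level. Going by the values given here, their separation, a 1.1-fold higher number from compound 1 to compound 2 (0.05 log units; within the scatter), is the only measured step, and it concerns (the fact that compounds 1 and 2 differ only in the configuration as drawn). Compound 3 `CCCCCCCC/C=C\CCCCCCCCOC[C@@H]1CCCN1[S+]([O-])c1ccc(C)cc1` departs from compound 1 elsewhere, through (a group of 9 heavy atoms (7 carbon, 1 oxygen, 1 sulfur; one six-membered aromatic ring of carbon only) in place of a hydrogen atom, on an amine nitrogen in a ring). Among the compounds with values here, the measured step therefore offers little guidance, since no measured compound carries any change on that nitrogen. A modest weakening is tentatively expected in this assay, with the estimated change being a 2.1-fold higher number from compound 1 to compound 3 (0.33 log units; beyond the scatter). For compound 3 the expected value is 10000 nM, with an estimated range of 3000 nM to 35000 nM.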

Compound 3, half-maximal inhibitory concentration: > 100000 nM
Compound 3: a limit, no number; the forecaster's own chance of this, stated with the estimate: 15%; middle value at least 10-fold (1.00 log units) away from the limit.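

Going by these compounds alone, the first change on the amine nitrogen in the ring shows that this position is far from indifferent in this assay: replacing the hydrogen atom with the group of 9 heavy atoms gives an at least 21-fold higher number from compound 1 to compound 3 (1.32 log units; beyond the scatter). The earlier step, confined to the double-bond configuration, gave no such sign. The reading for compound 3 is a limit, not a number: the limit of > 100000 nM in this assay, at which 1 of the 3 values shown sits.

On these data alone, the true size of the step therefore stays open. The compounds shown also leave open whether a methyl or benzyl group on this nitrogen would weaken compound 1 as much.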